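Shortening the chain of compound 3

This account rests on a few compounds, and the source may have more. Where it says the series, first, only, none or still open, it means among the compounds named here.

Compound 1 `CCCC/C=C\CCCCCCCCCc1cc(=O)c2c(O)cc(O)c(C)c2o1` gives 6790 nM
Compound 2 `CCCCC1(O)CC(=O)c2c(O)cc(O)cc2O1` gives > 87000 nM (a limit, not a number)
Compound 3 `CCCCCCCCCCCCCCCCCCCC1(O)CC(=O)c2c(O)cc(O)cc2O1` gives > 87000 nM (a limit, not a number)

All three were tested in a functional assay on MDA-MB-231 cells (Homo sapiens) for antiproliferative activity, read by MTT assay; on this read-out lower numbers stand for stronger inhibition and higher numbers for weaker inhibition. Compound 3 has no true number here: its entry, > 87000 nM, is a limit of the assay. The same limit is shared with compound 2, so the picture is the limit of > 87000 nM in this assay, at which 2 of the 3 values shown sit. Only compound 1, whose core differs from that of the other two, reaches a true number.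

Compound 4 `CCCCCCCCCCCC1(O)CC(=O)c2c(O)cc(O)cc2O1` keeps the core of compound 3. The change is hydrogen in place of octyl on a saturated chain carbon, ten or more bonds along the chain from a saturated ring carbon. The resulting chain is shorter than in compound 3 but longer than in compound 2, so compound 4 falls between two compounds that both stop at a limit.

No step beyond the usual scatter is expected in this assay, because the limit of > 87000 nM in this assay, at which 2 of the 3 values shown sit, is all that this core has shown so far. A limit is also the likeliest report for compound 4. The estimate amounts to an expected at least 1.2-fold lower number from compound 3 to compound 4 (0.09 log units; that floor lies within the scatter). For compound 4 the estimated value is 70000 nM, with an expected range of 25000 nM to 130000 nM.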

Compound 4, half-maximal inhibitory concentration: 42800 nM
Compound 4: the middle estimate sits 1.6-fold (0.21 log units) above what was measured; low and high end bracket the measured number.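

In this assay, for the compounds shown here, compound 4 gives the only true number among the compounds that share this core, which shows that the length of this chain can lift the core off the limit. Taking octyl off the longer chain gives an at least 2.0-fold lower number from compound 3 to compound 4 (0.30 log units; that floor lies within the scatter), and adding heptyl to the shorter chain gives an at least 2.0-fold lower number from compound 2 to compound 4 (0.30 log units; that floor lies within the scatter); both are floors, so the real size of each step stays unknown. Within this core, a true number appears only for the chain of intermediate length, while the shorter and longer chains stay at the limit: the limit of > 87000 nM in this assay, at which 2 of the 4 values shown sit.

From the compounds shown here alone, what remains open is how narrow this window of chain length is, since a nonyl or a tridecyl chain on the same core could sit at the limit or give a clearer number than compound 4. Going by these compounds, it is also open whether the chain must be purely carbon and hydrogen, or whether one carrying an amine or a carboxylic acid would keep, lose or improve the activity seen for compound 4.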